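The compounds below may be only part of what the source reports. "The series", "measured", "known", "first", "only" and "open" are said of these compounds alone.

Working notes on the series in a functional assay on KOPN-8 cells (Homo sapiens) for antiproliferative activity, with a stated time of 72 h; on this read-out higher numbers stand for an effect only at larger amounts of compound and lower numbers for an effect already at smaller amounts. Compound 1 `COc1ccc(-c2cc(=O)c3c(OC)cc(OC)cc3n2C)cc1` carries a methyl on the aromatic nitrogen of the shared core; in this assay compound 1 gives 30000 nM. Compound 2 `COc1ccc(-c2cc(=O)c3c(OC)cc(OC)cc3n2S(=O)(=O)c2ccc(C=O)cc2)cc1` bears a (4-formylphenyl)sulfonyl on that nitrogen instead; in this assay compound 2 reaches only a limit, > 34400 nM. Compound 3 `COc1ccc(-c2cc(=O)c3c(OC)cc(OC)cc3n2S(=O)(=O)c2ccc(OC)cc2)cc1` bears a (4-methoxyphenyl)sulfonyl on the same nitrogen; in this assay compound 3 likewise reaches only a limit, > 82700 nM. The step of an at least 1.1-fold higher number from compound 1 to compound 2 (0.05 log units; that floor lies within the scatter) and the step of an at least 2.7-fold higher number from compound 1 to compound 3 (0.44 log units; beyond the scatter) both run toward larger numbers, the second one beyond the scatter. The step that the two limits leave unreadable from compound 2 to compound 3 cannot be read, both ends being limits (the limit of > 34400 nM in this assay, at which 1 of the 3 values shown sits, (the limit of > 82700 nM in this assay, at which 1 of the 3 values shown sits)). Compound 3 therefore stands at a limit, with no resolved number.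

Compound 4 `COc1ccc(-c2cc(=O)c3c(OC)cc(OC)cc3n2S(=O)(=O)c2ccc(Br)s2)cc1` differs from compound 3 by 5-bromothiophen-2-yl in place of 4-methoxyphenyl on a sulfonyl sulfur. Within the data shown here, no measured step exchanges the group on the sulfonyl sulfur in a readable way; both sulfonyl-bearing compounds measured so far sit at limits. Compound 4 is therefore expected to sit at or near a limit, with the step of an at least 1.0-fold lower number from compound 3 to compound 4 (0.01 log units; that floor lies within the scatter) expected to stay within the scatter. The estimate for compound 4 is 80000 nM, in the range 25000 nM to 250000 nM.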

Compound 4, half-maximal effective concentration: > 48200 nM
Compound 4: a limit, no number (the forecaster's own chance of this, stated with the estimate: 70%); the middle value is on the limit's open side.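

In this assay compound 4 also gives only a limit, > 48200 nM, so a five-membered aromatic ring carrying bromine on the sulfonyl sulfur joins the two six-membered aromatic rings in yielding no resolved number. Against methyl on the aromatic nitrogen, the change to (5-bromothiophen-2-yl)sulfonyl reads as an at least 1.6-fold higher number from compound 1 to compound 4 (0.20 log units; that floor lies within the scatter), and this step alone does not separate the new group from methyl. The steps among the three sulfonyl-bearing compounds cannot be read, both ends being limits: the limit of > 48200 nM in this assay, at which 1 of the 4 values shown sits.

From the compounds shown here alone, whether any group on the sulfonyl sulfur gives a resolved number remains open, for instance a phenyl ring carrying an amine or a carboxylic acid. Also open, going by these compounds, is how a longer chain such as propyl in place of methyl on the aromatic nitrogen would compare with compound 1.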